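A few compounds are considered here, and "the series" means these few. Any claim that something is new, unique, unknown or untested is made for them only; others in the source may bear on it.

Measured so far in a physicochemical assay for lipophilicity, using the shake flask method, in phosphate buffer, measured as octanol-water partition, with a stated time of 24 h, at pH 7.4, tested at 100 uM; a higher number here means a more lipophilic compound, a lower number a more polar compound:
- compound 1 `Cc1cc(OCc2ccccc2)cc(C)c1-c1cccc(COc2ccc(OCC(=O)O)c(F)c2)c1` gives "not determined" (no result reported)
- compound 2 `COc1cc(C)c(-c2cccc(COc3ccc(OCC(=O)O)c(F)c3)c2)c(C)c1` gives 3.2

Among the compounds with values here, compound 2 holds the only number, so it cannot yet be ranked against anything. Compound 3 `Cc1cc(OCCCO)cc(C)c1-c1cccc(COc2ccc(OCC(=O)O)c(F)c2)c1` is still to be measured. It differs from compound 2 by 2-hydroxyethyl in place of hydrogen on a saturated chain carbon bound to an oxygen on an aromatic ring in the core they share: read one bond further out, methoxy becomes 3-hydroxypropoxy. Within the data shown here, no measured step speaks to this change, so the expectation in this assay rests on the structure alone: a downward step, modestly beyond the scatter. The estimated change is a number 0.50 log units lower from compound 2 to compound 3 (beyond the scatter) in this measurement. For compound 3 the estimated value is 2.7 within an expected range of 2.3 to 3.1 for the coming result.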

Compound 3, distribution coefficient: 2.73
Beside the measured number, compound 3's estimate is 0.03 log units below it, and the stated range covers the measured number.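

In this assay, the site on a saturated chain carbon bound to an oxygen on an aromatic ring now has its first measured step: going from methoxy to 3-hydroxypropoxy gives a number 0.47 log units lower from compound 2 to compound 3 (beyond the scatter). The series therefore shows that this change at this position moves the read-out beyond the scatter, which compound 2 alone could not show. No available evidence bears on the reason for this step.

From the compounds shown here alone, whether the step follows the added chain or its hydroxyl remains open. Propoxy and 3-aminopropoxy analogues, which would help separate the two, are not among the compounds shown.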